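Methylating a phenol on the side-chain aryl ring

The source may hold more compounds than are shown below. What is called first, only, known or untested is meant among the compounds shown, and "the series" means these compounds.

Measured compounds:
- compound 1, `COc1cccc([C@H](O)[C@H]2CO[C@H](c3ccc(OC)c(OC)c3)[C@@H](C/C=C/c3ccc(OC)c(OC)c3)C2)c1`: 21200 nM
- compound 2, `Cc1ccc(/C=C/C[C@H]2C[C@@H]([C@@H](O)c3ccccc3)CO[C@@H]2c2ccccc2)cc1C`: 10000 nM
- compound 3, `Oc1cccc(/C=C/C[C@H]2C[C@@H]([C@@H](O)c3ccccc3)CO[C@@H]2c2ccccc2)c1`: 18600 nM

Of the compounds shown here, three with a shared core have been tested in a functional assay on HeLa cells (Homo sapiens) for cytotoxicity, read by WST assay, with a stated time of 48 h; on this read-out higher numbers stand for weaker inhibition and lower numbers for stronger inhibition. Compound 1 gives 21200 nM, compound 2 gives 10000 nM and compound 3 gives 18600 nM. Compound 3 thus sits among numbers that all lie within the usual scatter of one another, so no ordering among them can be claimed. Within the data shown here, the one step among them, a 1.9-fold higher number from compound 2 to compound 3 (0.27 log units; within the scatter), shows that swapping the aryl group on the double-bonded chain did not move the number beyond the scatter.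

Compound 4, `COc1cccc(/C=C/C[C@H]2C[C@@H]([C@@H](O)c3ccccc3)CO[C@@H]2c2ccccc2)c1`, differs from compound 3 by methyl in place of hydrogen on an oxygen on an aromatic ring. Among the measured compounds shown here, no measured pair shows this particular change of hydroxy to methoxy, so the only guide is that the neighbouring aryl change gave a 1.9-fold higher number from compound 2 to compound 3 (0.27 log units; within the scatter), and that compound 1, which carries methoxy groups, gives 21200 nM. A small step, if any, is expected: a 1.1-fold lower number from compound 3 to compound 4 (0.04 log units; within the scatter). Compound 4 is therefore estimated at 17000 nM, with a range from 6000 nM to 45000 nM.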

Compound 4, half-maximal inhibitory concentration: 10900 nM
For compound 4 the middle estimate is 1.6-fold (0.19 log units) above the measured one, and the stated range covers the measured number.
By their numbers in this assay, from the lowest: compounds 2, 4, 3 and 1 (each within the scatter of the next, the first and the last beyond it).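

In this assay, among these compounds, turning the hydroxy group of the 3-hydroxyphenyl ring into methoxy gives a 1.7-fold lower number from compound 3 to compound 4 (0.23 log units; within the scatter) and stays within the scatter, so this is the first direct reading of a change on this oxygen, and it shows no clear effect. Replacing 3,4-dimethylphenyl with 3-methoxyphenyl gives a 1.1-fold higher number from compound 2 to compound 4 (0.04 log units; within the scatter) and also stays within the scatter, so none of the three aryl groups tried on the double-bonded chain can be told apart from another by these steps. Nothing available explains why these changes alter the number so little.

Still open, as far as these compounds go, is whether a longer chain on this oxygen, such as ethoxy, would move the number beyond the scatter. The same question stands for an amine or a carboxylic acid in place of the methoxy group on this ring.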